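Compound 3: 4-methoxyphenyl in place of 2-methoxyphenyl

The compounds below may be only part of what the source reports. "The series", "measured", "known", "first", "only" and "open" are said of these compounds alone.

Of the compounds shown here, two carry a number so far. Compound 1 `COc1ccccc1/C=C/C(=O)/C=C/c1ccc(OCc2cn(CCOc3cc(=O)oc4ccccc34)nn2)c(OC)c1` gives, in a functional assay on HCT-116 cells (Homo sapiens) for inhibition, read by sulforhodamine B assay, with a stated time of 48 h, tested at 50 uM (on this read-out higher numbers stand for more inhibition of growth at the one concentration tested and lower numbers for less inhibition of growth), a growth inhibition of 70%. Compound 2 `COc1cc(/C=C/C(=O)/C=C/c2cccc3ccccc23)ccc1OCc1cn(CCCCOc2cc(=O)oc3ccccc23)nn1` gives in this assay a growth inhibition of 56%. Compound 1 thus stands highest of the two; its nearest neighbour, compound 2, lies lower by a gap that is beyond the scatter of this read-out. Among the compounds with values here, the two measured compounds differ from each other in more than one place, so no single structural step between measured compounds can be read from them.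

Compound 3 `COc1ccc(/C=C/C(=O)/C=C/c2ccc(OCc3cn(CCOc4cc(=O)oc5ccccc45)nn3)c(OC)c2)cc1` has not yet been measured in this assay. It keeps every atom of compound 1 and differs only in how they are joined: 4-methoxyphenyl in place of 2-methoxyphenyl on a double-bonded chain carbon bound to a double-bonded chain carbon. The shared core of compound 1 and compound 3 is untouched.

Within the data shown here, with no single step on record, the expected change from compound 1 to compound 3 in this assay is small, most likely none beyond the scatter, and it is estimated as a number 5 percentage points lower from compound 1 to compound 3 (within the scatter). Compound 3 is therefore expected to give about 65%, within a range from 45% to 85%.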

Compound 3, percent growth inhibition at one concentration: 71%
Beside the measured number, compound 3's estimate is 6 percentage points below it, within the range that was stated.
By their numbers in this assay, from the lowest: compound 2; then compounds 1 and 3 (each within the scatter of the next).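

In this assay, the exchange of 2-methoxyphenyl for 4-methoxyphenyl on a double-bonded chain carbon bound to a double-bonded chain carbon gives a number 1 percentage points higher from compound 1 to compound 3 (within the scatter), so this read-out at the one concentration tested does not separate the two groups. Within the data shown here, this is the first single-place step on record for the series, and it shows that at this position the same atoms can be joined in either of these two ways without a difference beyond the scatter. Nothing on record explains this result or links either group to a measured property.

Still open, going by these compounds, is whether this position accepts only methoxyphenyl groups or also bears other groups, such as an unsubstituted phenyl or a phenyl carrying an amine or a carboxylic acid, without a step beyond the scatter. Also open, on these data alone, is whether compound 1 and compound 3 would separate at lower concentrations, since this assay gives a reading at one concentration and no full concentration-response comparison of the two.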